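Turning the nitro compound's double bond from E to Z

This account rests on a few compounds, and the source may have more. Where it says the series, first, only, none or still open, it means among the compounds named here.

Compound 1 `COCCOc1cc(/C=C\c2ccc3ccccc3c2)ccc1OC`: 2990 nM
Compound 2 `COc1ccc(/C=C/c2ccc3ccccc3c2)cc1F`: > 5000 nM (a limit)
Compound 3 `COc1ccc(/C=C/c2ccc3ccccc3c2)cc1[N+](=O)[O-]`: > 5000 nM (a limit)

In a functional assay on A549 cells (Homo sapiens) for inhibition (a lower number here means a stronger inhibitor, a higher number a weaker inhibitor), compound 3 gives > 5000 nM, which is a limit and not a number. Compound 2 stands at the same limit. Compound 4 `COc1ccc(/C=C\c2ccc3ccccc3c2)cc1[N+](=O)[O-]` is related to compound 3 by a single change: the two compounds have the same atoms and bonds and differ only in configuration as drawn: 1 of 1 stereo elements differ; a double bond is drawn E in compound 3 and Z in compound 4.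

For the measured compounds named here, the one measured step is a step that the two limits leave unreadable from compound 2 to compound 3, so it offers no size to carry over, and no measured step isolates this change. Going by the values given here, the only other guide is drawn Z like compound 4 but carries different groups. In this assay compound 1, that guide, gives 2990 nM. On that single value, a move towards stronger inhibition is expected, though its size is poorly defined and compound 4 could yet stay at the limit. The expected step is an at least 2.7-fold lower number from compound 3 to compound 4 (0.44 log units; beyond the scatter). For compound 4 the estimated half-maximal inhibitory concentration is 1800 nM, with an expected range of 300 nM to 5000 nM.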

Compound 4, half-maximal inhibitory concentration: > 20000 nM
Compound 4 was reported as a limit; the forecaster's own chance of this, stated with the estimate: 30%; middle value at least 11-fold (1.04 log units) away from the limit.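

In this assay, turning the double bond from E to Z leaves the nitro compound without a readable value: compound 4 gives > 20000 nM, which is a limit and not a number. For the compounds shown here, with the double bond drawn Z in both compounds, a substituent change at this aromatic carbon can now be sized for the first time, as nitro in place of 2-methoxyethoxy is an at least 6.6-fold higher number from compound 1 to compound 4 (0.82 log units; beyond the scatter). The steps among compound 2, compound 3 and compound 4 cannot be read, so the size of any effect of configuration alone stays unknown, even though the comparison is a clean one: the fact that compounds 3 and 4 differ only in the configuration as drawn

On these data alone, it remains open how an amine on this carbon would read in the Z series. As far as these compounds go, a longer chain in place of 2-methoxyethoxy, and the E form of compound 1, are equally open.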